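The source may report more compounds than this note shows. Statements on the series, on what has been measured and on what is new or still open speak of the compounds shown alone.

Measured so far:
compound 1, `CCn1c(C(=O)N[C@@H](C)C(=O)OC)ccc1C(CC)(CC)c1ccc(OCS(=O)(=O)c2ccccc2)c(C)c1` — > 50000 nM
compound 2, `CCn1c(C(=O)NCCN)ccc1C(CC)(CC)c1ccc(OCS(=O)(=O)c2ccccc2)c(C)c1` — 6890 nM

Both were tested in a functional assay on PC-3 cells (Homo sapiens) for antiproliferative activity, read by MTT assay, with a stated time of 24 h; on this read-out higher numbers stand for weaker inhibition and lower numbers for stronger inhibition. For compound 1 the result is not a number but a limit of the assay, (the limit of > 50000 nM in this assay, at which 1 of the 2 values shown sits), so compound 1 stands at the weak end of what this assay can report. Within the data shown here, compound 2 gives 6890 nM, and the one step measured is an at least 7.2-fold lower number from compound 1 to compound 2 (0.86 log units; beyond the scatter).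

The compound now in question is compound 3, `CCN(CC)CCNC(=O)c1ccc(C(CC)(CC)c2ccc(OCS(=O)(=O)c3ccccc3)c(C)c2)n1CC`. It differs from compound 1 in one place: 2-(diethylamino)ethyl in place of 1-(methoxycarbonyl)ethyl on an amide-type nitrogen. Among the measured compounds shown here, the only measured step that bears on this change is the one from compound 1 to compound 2, where a small chain ending in a nitrogen likewise replaced the 1-(methoxycarbonyl)ethyl group and the number fell by at least a modest amount. Compound 3 carries a related chain, 2-(diethylamino)ethyl, so a step of similar size and direction is expected in this assay. The expected step is an at least 7.1-fold lower number from compound 1 to compound 3 (0.85 log units; beyond the scatter), which is an estimate. Compound 3 is therefore estimated at 7000 nM, with a likely range from 2500 nM to 25000 nM.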

Compound 3, half-maximal inhibitory concentration: 7130 nM
Compound 3: middle estimate off by 1.0-fold (0.01 log units), on the low side; low and high end bracket the measured number.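

In this assay, a second chain ending in a nitrogen, 2-(diethylamino)ethyl, also lies well below the methoxycarbonyl-bearing compound (with an at least 7.0-fold lower number from compound 1 to compound 3 (0.84 log units; beyond the scatter)), so the drop seen with compound 2 is no longer tied to a single chain. Going by these compounds, for compound 1 the reading is a limit of the assay and not a number, so the true size of this step stays unknown: the limit of > 50000 nM in this assay, at which 1 of the 3 values shown sits. The new information is at the end of the chain, where two ethyl groups on the nitrogen leave the result within the scatter (with a 1.0-fold higher number from compound 2 to compound 3 (0.01 log units; within the scatter)), so diethylamino and amino cannot be told apart at this position in this assay.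

Both compounds that lie below compound 1 carry a nitrogen at the chain end and lack the methoxycarbonyl group and the defined stereocentre, so these compounds cannot show which of these differences matters; a plain butyl chain with no nitrogen, or a carboxylic acid in place of the methyl ester, would separate them. Also open, on these data alone, is how far the chain can vary, for example with a longer chain such as 3-aminopropyl or with a ring amine such as morpholine at its end.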